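Shortening the Alkoxy Chain from Hexyl to Sec-Butyl

The compounds below may be only part of what the source reports. "The series", "measured", "known", "first", "only" and "open" are said of these compounds alone.

Compound 3 `CCCCCCOc1c(-c2cc(OC)c(OC)c(OC)c2)oc2ccccc2c1=O` yields only a limit in a functional assay on DU-145 cells (Homo sapiens) for antiproliferative activity, read by WST assay, with a stated time of 3 days (on this read-out higher numbers stand for weaker inhibition and lower numbers for stronger inhibition), namely > 50000 nM. Among the measured compounds shown here, compound 3 is the one value that rests at the limit of > 50000 nM in this assay, at which 1 of the 3 values shown sits. Its measured relatives are compound 1 `CCOc1c(-c2cc(OC)c(OC)c(OC)c2)oc2ccccc2c1=O` at 6200 nM and compound 2 `CCCOc1c(-c2cc(OC)c(OC)c(OC)c2)oc2ccccc2c1=O` at 2800 nM. Compound 4 `CCC(C)Oc1c(-c2cc(OC)c(OC)c(OC)c2)oc2ccccc2c1=O` differs from compound 3 in one place: sec-butyl in place of hexyl on an oxygen on an aromatic ring. Within this series, the step from compound 1 to compound 2 gave a 2.2-fold lower number from compound 1 to compound 2 (0.35 log units; beyond the scatter), whereas the longer chain gave an at least 8.0-fold higher number from compound 1 to compound 3 (0.90 log units; beyond the scatter) and an at least 17-fold higher number from compound 2 to compound 3 (1.25 log units; beyond the scatter). As sec-butyl stands between propyl and hexyl, a return toward the potency of compound 2 is expected, though perhaps not fully. Compound 4 is therefore estimated at 7000 nM, with a range of 2000 nM to 30000 nM. This estimate corresponds to an expected at least 7.1-fold lower number from compound 3 to compound 4 (0.85 log units; beyond the scatter).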

Compound 4, half-maximal inhibitory concentration: > 50000 nM
Compound 4: only a limit was reported; the forecaster's own chance of this, stated with the estimate: 15%; middle value at least 7.1-fold (0.85 log units) from the limit.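

In this assay, sec-butyl on this oxygen does not keep the activity of the shorter chains, giving an at least 17-fold higher number from compound 2 to compound 4 (1.25 log units; beyond the scatter) and an at least 8.0-fold higher number from compound 1 to compound 4 (0.90 log units; beyond the scatter). The loss is therefore not confined to hexyl. Compound 4, like compound 3, rests at a limit, and the step that joins them cannot be read: the limit of > 50000 nM in this assay, at which 2 of the 4 values shown sit.

The compounds shown leave open whether the loss follows chain length or the branch in sec-butyl. A straight butyl chain or an isopropyl group on this oxygen would separate the two.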